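A few compounds are considered here, and "the series" means these few. Any claim that something is new, unique, unknown or untested is made for them only; others in the source may bear on it.

Working notes on the series. The shared core is kept throughout, and only the aryl group on the ring nitrogen changes. Compound 1 `Nc1scc(CN2CCN(c3cccc(Cl)c3Cl)CC2)c1C(=O)c1ccc(Cl)cc1` gives -57% in a functional assay on CHO cells with adenosine receptor A1 (Homo sapiens) as the target, read by cAMP accumulation and immunoassay, with a stated time of 6 min, tested at 1 uM; a higher number here means a weaker effect of the compound at the concentration tested, a lower number a stronger effect. For the measured compounds named here, compound 2 `Nc1scc(CN2CCN(c3ccc(F)cc3Cl)CC2)c1C(=O)c1ccc(Cl)cc1` gives -39% in this assay, the highest of the two numbers so far; the step of a number 18 percentage points higher from compound 1 to compound 2 (beyond the scatter) is the only measured one, and it exchanges one halogen pattern on that phenyl for another. Compound 3 `Nc1scc(CN2CCN(c3ccc(F)c(Cl)c3)CC2)c1C(=O)c1ccc(Cl)cc1` is not yet measured. Its difference from compound 2 is 3-chloro-4-fluorophenyl in place of 2-chloro-4-fluorophenyl on an amine nitrogen in a ring. Going by the values given here, the one step that bears on this is a number 18 percentage points higher from compound 1 to compound 2 (beyond the scatter), a modest change from rearranging halogens on the same phenyl, so a step of comparable or smaller size is expected here, with its direction not fixed by the data. For compound 3 the estimate is -48%, between -72% and -20%, meaning an expected step of a number 9 percentage points lower from compound 2 to compound 3 (within the scatter).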

Compound 3, a percentage reported as activity, at one concentration (the size of the read-out at that concentration, not a potency): -60%
Beside the measured number, compound 3's estimate is 12 percentage points above it; the measured number falls inside the stated range.
By their numbers in this assay, from the lowest: compounds 3 and 1 (each within the scatter of the next); then compound 2.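

With the same atoms on the phenyl, the exchange of 2-chloro-4-fluorophenyl for 3-chloro-4-fluorophenyl gives a number 21 percentage points lower from compound 2 to compound 3 (beyond the scatter) in this assay, so the arrangement of the halogens at this position on the amine nitrogen changes the read-out even when their identity does not. The step of a number 3 percentage points lower from compound 1 to compound 3 (within the scatter) shows that 3-chloro-4-fluorophenyl and 2,3-dichlorophenyl cannot be told apart here, although they carry different halogens, and both bear a chlorine at the 3 position named in these groups, which 2-chloro-4-fluorophenyl does not. No measurement at hand gives a cause for these differences.

The compounds shown leave open whether the 3-chloro group alone accounts for the pattern, since each of these three phenyl groups carries two halogens. As far as these compounds go, how a methoxy or trifluoromethyl group on this phenyl would read in this assay also remains open.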